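Swapping the Aryl Group: Expected Cytotoxicity of Compound 3

This account rests on a few compounds, and the source may have more. Where it says the series, first, only, none or still open, it means among the compounds named here.

Compound 2 `COc1nc(-c2ccc(C#N)cc2)ccc1[C@@H](c1ccccc1)[C@@](O)(CCN(C)C)c1cccc2ccccc12` carries a 4-cyanophenyl group on its core. In a toxicity assay on Vero cells (Chlorocebus sabaeus) for cytotoxicity (a lower number here means that less compound is tolerated, a higher number that more compound is tolerated), compound 2 gives > 50 ug/mL, which is a limit of the assay and not a number; this is the limit of > 50 ug/mL in this assay, at which 1 of the 2 values shown sits. Compound 1 `COc1nc(C2CCCCC2)ccc1[C@@H](c1ccccc1)[C@@](O)(CCN(C)C)c1cccc2ccccc12` has a cyclohexyl group in that place, and in this assay compound 1 gives 32.3 ug/mL. The change from compound 1 to compound 2 brought an at least 1.5-fold higher number from compound 1 to compound 2 (0.18 log units; that floor lies within the scatter).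

Compound 3 `COc1nc(-c2cccc(F)c2)ccc1[C@@H](c1ccccc1)[C@@](O)(CCN(C)C)c1cccc2ccccc12` has not yet been measured. Its difference from compound 2 is 3-fluorophenyl in place of 4-cyanophenyl on an aromatic carbon. Among the measured compounds shown here, the only measured step, an at least 1.5-fold higher number from compound 1 to compound 2 (0.18 log units; that floor lies within the scatter), concerns a different exchange and has a floor within the scatter, so it says little about replacing one aromatic ring with another. The change from compound 2 to compound 3 is therefore expected to give an at least 1.1-fold lower number from compound 2 to compound 3 (0.04 log units; that floor lies within the scatter), nothing beyond the scatter. Compound 3 is expected to give about 45 ug/mL in this assay, within a range of 22 ug/mL to 90 ug/mL.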

Compound 3, half-maximal cytotoxic concentration: > 50 ug/mL
Compound 3 was reported as a limit (the forecaster's own chance of this, stated with the estimate: 45%); at least 1.1-fold (0.04 log units) between middle value and limit.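

At this place on the core, a second aromatic ring also reaches the top of the tested range: in this assay compound 3 gives > 50 ug/mL, which is a limit of the assay and not a number. Putting 3-fluorophenyl where the cyclohexyl group stood gives an at least 1.5-fold higher number from compound 1 to compound 3 (0.18 log units; that floor lies within the scatter), so this exchange, like the one to 4-cyanophenyl, has a floor that does not clear the scatter. The step between compound 2 and compound 3 cannot be read because both sit at the same ceiling: the limit of > 50 ug/mL in this assay, at which 2 of the 3 values shown sit.

How far past that limit either compound lies remains open, so the compounds shown cannot separate the nitrile from the fluorine. Also open, on these data alone, is whether an amine or a carboxylic acid at this place would keep the number at the limit or bring it down.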